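A few compounds are considered here, and "the series" means these few. Any claim that something is new, unique, unknown or untested is made for them only; others in the source may bear on it.

Measured so far:
compound 1 `Oc1cccc(-c2cc(-c3ccc(Cl)cc3)nc(-c3cccs3)c2)c1` — 9280 nM
compound 2 `Oc1cccc(-c2cc(-c3cccc(Cl)c3)nc(-c3ccco3)c2)c1` — 2460 nM

In a functional assay on HCT-15 cells (Homo sapiens) for cytotoxicity, read by CCK-8 assay and cell counting, with a stated time of 2 days (a lower number here means a stronger inhibitor, a higher number a weaker inhibitor), compound 2 gives 2460 nM, the lowest of the two numbers; compound 1 gives 9280 nM, a higher number, and the gap between them lies beyond the scatter. Within the data shown here, the two differ in two places at once, so no single step can be drawn from them. Compound 3 `Oc1cccc(-c2cc(-c3cccc(Cl)c3)nc(-c3cccs3)c2)c1` differs from compound 2 in one place only: thiophen-2-yl in place of furan-2-yl on an aromatic carbon. Among the measured compounds shown here, with no measured step of this kind to lean on, the expected step of a 1.4-fold higher number from compound 2 to compound 3 (0.15 log units; within the scatter) is small, not beyond the scatter. Compound 3 is therefore expected to give 3500 nM, within a range of 1500 nM to 9000 nM.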

Compound 3, half-maximal inhibitory concentration: 2610 nM
For compound 3 the middle estimate is 1.3-fold (0.13 log units) above the measured one; the measured number falls inside the stated range.
By their numbers in this assay, from the lowest: compounds 2 and 3 (each within the scatter of the next); then compound 1.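

In this assay, thiophen-2-yl in place of furan-2-yl on this aromatic carbon gives a 1.1-fold higher number from compound 2 to compound 3 (0.03 log units; within the scatter) and so leaves the read-out unchanged within the scatter. With 3-chlorophenyl in place of 4-chlorophenyl, the same thiophen-2-yl series gives a 3.6-fold lower number from compound 1 to compound 3 (0.55 log units; beyond the scatter), so here the place of the chlorine on the phenyl ring matters more. No measured evidence accounts for either step. Still open, going by these compounds, is whether an amine or a longer alkyl chain on this carbon would fit as well as the two five-membered rings do.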